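A few compounds are considered here, and "the series" means these few. Any claim that something is new, unique, unknown or untested is made for them only; others in the source may bear on it.

Notes on the series. For the measured compounds named here, compound 1 `CC1=CC[C@@H]([C@@](C)(O)CCCC(C)(C)NC(=S)N/N=C\c2ccccc2)CC1` bears a plain phenyl on the carbon with a double bond to nitrogen and is the only member with a numerical value: in a functional assay on HT-29 cells (Homo sapiens) for cytotoxicity, read by sulforhodamine B assay (on this read-out lower numbers stand for higher toxicity in this test and higher numbers for lower toxicity in this test), compound 1 gives 57400 nM. Compound 2 `CC1=CC[C@@H]([C@@](C)(O)CCCC(C)(C)NC(=S)N/N=C\c2ccc(C)cc2)CC1` reaches only a limit in this assay, where compound 2 gives > 100000 nM. Compound 3 `CC1=CC[C@@H]([C@@](C)(O)CCCC(C)(C)NC(=S)N/N=C\c2ccccc2Cl)CC1` likewise ends at a limit, as compound 3 gives > 100000 nM. The two measured steps, an at least 1.7-fold higher number from compound 1 to compound 2 (0.24 log units; that floor lies within the scatter) and an at least 1.7-fold higher number from compound 1 to compound 3 (0.24 log units; that floor lies within the scatter), both run into (the limit of > 100000 nM in this assay, at which 2 of the 3 values shown sit); between the two limits the step that the two limits leave unreadable from compound 2 to compound 3.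

Compound 4 `CC1=CC[C@@H]([C@@](C)(O)CCCC(C)(C)NC(=S)N/N=C\c2cccc(Cl)c2)CC1` differs from compound 1 by chloro in place of hydrogen on an aromatic carbon. Going by the values given here, the step that bears on it is the one from compound 1 to compound 3, where chloro in place of hydrogen on an aromatic carbon also entered and gave an at least 1.7-fold higher number from compound 1 to compound 3 (0.24 log units; that floor lies within the scatter). On that basis compound 4 is expected to move the same way, with the step estimated as a 1.7-fold higher number from compound 1 to compound 4 (0.24 log units; within the scatter). The estimate for compound 4 is 100000 nM, within a range from 45000 nM to 250000 nM, and a limit rather than a number is the more likely report.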

Compound 4, concentration lethal to 50% of the cells: 45900 nM
Estimate against measurement, compound 4: 2.2-fold (0.34 log units) above; the measured number falls inside the stated range.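

Chloro in place of hydrogen, meta to a large group, does not by itself carry the compound to the limit of the test, as the step reads a 1.3-fold lower number from compound 1 to compound 4 (0.10 log units; within the scatter) and stays small. The place of the chloro on the ring does count in this assay, since the change from the chloro of compound 3 to the 3-chlorophenyl of compound 4 gives an at least 2.1-fold lower number from compound 3 to compound 4 (0.33 log units; beyond the scatter) as a step beyond the scatter. The 3-chlorophenyl is also set apart from the methyl-bearing ring of compound 2, with an at least 2.1-fold lower number from compound 2 to compound 4 (0.33 log units; beyond the scatter) as the step.

On these data alone, how far compounds 2 and 3 lie past their limits stays unknown, and the step between them cannot be read: (the limit of > 100000 nM in this assay, at which 2 of the 4 values shown sit). As far as these compounds go, whether a methoxy group or an amine on the same ring would behave like the chloro of compound 4 remains open.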